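A few compounds are considered here, and "the series" means these few. Any claim that something is new, unique, unknown or untested is made for them only; others in the source may bear on it.

Measured in a functional assay on A-431 cells (Homo sapiens) for antiproliferative activity, read by MTT assay, with a stated time of 72 h; on this read-out lower numbers stand for stronger inhibition and higher numbers for weaker inhibition:
- compound 1 `COc1cc2ncnc(Nc3cccc(Br)c3)c2cc1OCCCCC(=O)Nc1ccc(S(N)(=O)=O)cc1`: 9750 nM
- compound 2 `COc1cc2ncnc(Nc3ccc(Br)cc3)c2cc1OCCCCC(=O)Nc1ccc(S(N)(=O)=O)cc1`: 6570 nM
- compound 3 `COc1ccc(Nc2ncnc3cc(OC)c(OCCCCC(=O)Nc4ccc(S(N)(=O)=O)cc4)cc23)cc1OC`: 35400 nM

Compound 3 gives the highest number of the three; the steps of a 3.6-fold higher number from compound 1 to compound 3 (0.56 log units; beyond the scatter) and a 5.4-fold higher number from compound 2 to compound 3 (0.73 log units; beyond the scatter) both run the same way and both lie beyond the scatter, while a 1.5-fold lower number from compound 1 to compound 2 (0.17 log units; within the scatter) does not. Compound 4 `COc1ccccc1Nc1ncnc2cc(OC)c(OCCCCC(=O)Nc3ccc(S(N)(=O)=O)cc3)cc12` differs from compound 3 by 2-methoxyphenyl in place of 3,4-dimethoxyphenyl on a nitrogen on an aromatic ring. Among the measured compounds shown here, no measured step removes or shifts a methoxy on this ring, so the only bearing comes from the two steps above, which show that the 3,4-dimethoxyphenyl sits weaker than either bromophenyl in this assay. The change is therefore expected to give at most a small step in this assay, leaning toward a lower number, a 1.8-fold lower number from compound 3 to compound 4 (0.25 log units; within the scatter). Compound 4 is estimated at 20000 nM in this assay, within a range of 7000 nM to 60000 nM.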

Compound 4, half-maximal inhibitory concentration: 24200 nM
For compound 4 the middle estimate is 1.2-fold (0.08 log units) below the measured one, and the stated range covers the measured number.
By their numbers in this assay, from the lowest: compounds 2 and 1 (each within the scatter of the next); then compounds 4 and 3 (each within the scatter of the next).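

In this assay, 2-methoxyphenyl in place of 3,4-dimethoxyphenyl gives a 1.5-fold lower number from compound 3 to compound 4 (0.17 log units; within the scatter) and so does not separate these two methoxyphenyl groups. Among the compounds shown here, the gap to the bromophenyl compounds now appears with a second methoxyphenyl group, at a 3.7-fold higher number from compound 2 to compound 4 (0.57 log units; beyond the scatter) and a 2.5-fold higher number from compound 1 to compound 4 (0.39 log units; beyond the scatter) in the same direction as the earlier steps. Among the four compounds, both methoxyphenyl groups therefore give higher numbers than both bromophenyl groups.

As far as these compounds go, whether an unsubstituted phenyl, a 3-aminophenyl or a 4-carboxyphenyl on this nitrogen would follow the same order remains open. No measurement shown explains the gap between the methoxyphenyl and bromophenyl compounds.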